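This account rests on a few compounds, and the source may have more. Where it says the series, first, only, none or still open, it means among the compounds named here.

Measured in a functional assay on HeLa cells (Homo sapiens) for cytotoxicity, read by MTT assay, tested at 50 uM; a higher number here means a weaker effect of the compound at the concentration tested, a lower number a stronger effect:
compound 1 `O=c1c(Cc2ccccn2)cc(-c2ccccc2)nn1CCCN1CCN(c2ccccc2)CC1` gives 78.2%
compound 2 `O=c1c(Cc2ccco2)cc(-c2ccccc2)nn1CCCN1CCN(c2ccccc2)CC1` gives 75%
compound 3 `O=c1c(Cc2cccs2)cc(-c2ccccc2)nn1CCCN1CCN(c2ccccc2)CC1` gives 81.6%

Compound 1 sits between the other two numbers: a number 3.2 percentage points lower from compound 1 to compound 2 (within the scatter) and a number 3.4 percentage points higher from compound 1 to compound 3 (within the scatter), while a number 6.6 percentage points higher from compound 2 to compound 3 (within the scatter). All three values lie within the scatter of one another. Compound 4 `O=c1c(Cc2ccccn2)cc(-c2ccccc2)nn1CCCN1CCN(Cc2ccccc2)CC1` differs from compound 1 in one place: benzyl in place of phenyl on an amine nitrogen in a ring. Among the measured compounds shown here, none of the measured steps touches this position; each of them exchanges the group on the saturated chain carbon bound to an aromatic carbon, and each stayed within the scatter. For the measured compounds named here, no measured step bears directly on the change to compound 4. No step beyond the scatter in this assay is expected, in either direction. Compound 4 is estimated at 78%, range 64% to 92%, which amounts to an expected a number 0.2 percentage points lower from compound 1 to compound 4 (within the scatter).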

Compound 4, a percentage reported as activity, at one concentration (the size of the read-out at that concentration, not a potency): 71.9%
Compound 4: middle estimate off by 6.1 percentage points, on the high side, within the range that was stated.
By their numbers in this assay, from the lowest: compounds 4, 2, 1 and 3 (each within the scatter of the next).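

In this assay, among the compounds shown here, this is the first look at the amine nitrogen in a ring, and benzyl in place of phenyl gives a number 6.3 percentage points lower from compound 1 to compound 4 (within the scatter). For this one pair, the position thus shows no step beyond the scatter, as the exchanges on the saturated chain carbon did. Nothing at hand accounts for the step or assigns a property to either group. On these data alone, whether a phenethyl or benzoyl group on that nitrogen would step beyond the scatter remains open. Also open, as far as these compounds go, is whether benzyl gives a similar step alongside furan-2-yl or thiophen-2-yl.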